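From piperidin-4-yl to 4-cyclopropylphenyl

A few compounds are considered here, and "the series" means these few. Any claim that something is new, unique, unknown or untested is made for them only; others in the source may bear on it.

Measured so far:
- Compound 1 `COc1cccc(NC(=O)c2nnn(CC3CCNCC3)c2N)c1`: > 250000 nM (a limit)
- Compound 2 `COc1cccc(NC(=O)c2nnn(C(C)c3ccc(C(C)(C)C)cc3)c2N)c1`: 20000 nM

In a physicochemical assay for solubility, read by nephelometry, at pH 7.4 (a lower number here means a less soluble compound, a higher number a more soluble compound), compound 1 gives > 250000 nM, which is a limit of the assay and not a number. Compound 3 `COc1cccc(NC(=O)c2nnn(Cc3ccc(C4CC4)cc3)c2N)c1` has not yet been measured. It carries 4-cyclopropylphenyl in place of piperidin-4-yl on a saturated chain carbon bound to an aromatic nitrogen. For the measured compounds named here, no measured pair of compounds isolates this change, so the expectation rests on a single comparison. Like compound 3, compound 2 has no piperidin-4-yl, and in this assay compound 2 gives 20000 nM. A downward step well beyond the usual scatter is therefore expected, though its exact size stays uncertain while compound 1 has only a limit. The expected change is an at least 8.3-fold lower number from compound 1 to compound 3 (0.92 log units; beyond the scatter). For compound 3 the estimated value in this assay is 30000 nM, with an expected range of 8000 nM to 100000 nM.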

Compound 3, solubility: 79000 nM
Estimate against measurement, compound 3: 2.6-fold (0.42 log units) below; low and high end bracket the measured number.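

In this assay, for the compounds shown here, the change from piperidin-4-yl to 4-cyclopropylphenyl on a saturated chain carbon bound to an aromatic nitrogen now has a measured step of its own, which no earlier pair of compounds provided: it brings an at least 3.1-fold lower number from compound 1 to compound 3 (0.50 log units; beyond the scatter). The group at this position therefore moves the read-out beyond the scatter, and with 4-cyclopropylphenyl in place, compound 3 gives a number inside the range of the assay, 79000 nM. The step remains a bound whose true size could be larger, because compound 1 stands at a limit of the assay and not at a number: the limit of > 250000 nM in this assay, at which 1 of the 3 values shown sits.

This single step takes away piperidin-4-yl, with its nitrogen, and brings in the all-carbon 4-cyclopropylphenyl in the same exchange. Going by these compounds alone, it does not separate the departure of the one group from the arrival of the other. The compounds shown also leave open where a cyclohexyl group, which has a saturated carbon ring without nitrogen, or a 4-aminophenyl group, which has an aromatic ring with an amine, would fall in this assay.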